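From 2-methylbenzyl to 4-bromobenzyl: little change expected

The source may hold more compounds than are shown below. What is called first, only, known or untested is meant among the compounds shown, and "the series" means these compounds.

- compound 1 `Cc1ccccc1CSc1nnc(-c2ccc3c(c2)OCCO3)o1` gives 23900 nM as its value
- compound 2 `Cc1ccc(CSc2nnc(-c3ccc4c(c3)OCCO4)o2)cc1` gives 32500 nM as its value
- compound 3 `Clc1ccc(CSc2nnc(-c3ccc4c(c3)OCCO4)o2)cc1` gives 28400 nM as its value

These values come from a functional assay on SW 1116 cells (Homo sapiens) for antiproliferative activity, read by MTT assay, with a stated time of 48 h (a lower number here means a stronger inhibitor, a higher number a weaker inhibitor), and lie close together. Compound 1 cannot be separated from the other two, as its steps show: a 1.4-fold higher number from compound 1 to compound 2 (0.13 log units; within the scatter) and a 1.2-fold higher number from compound 1 to compound 3 (0.07 log units; within the scatter) are all that the data record.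

Compound 4 `Brc1ccc(CSc2nnc(-c3ccc4c(c3)OCCO4)o2)cc1` has not yet been measured. It differs from compound 1 in one place, on a saturated chain carbon bound to a sulfur, with 4-bromophenyl in place of 2-methylphenyl on a saturated chain carbon bound to a sulfur here. The most closely related change is the one to 4-chlorophenyl at that same place, and the swap of chloro for methyl also bears on it, with a 1.1-fold lower number from compound 2 to compound 3 (0.06 log units; within the scatter) as its size. Within the data shown here, no measured compound carries the 4-bromophenyl group, so this comparison has limits. No step beyond the scatter is therefore expected in this assay for this change, and the estimate is a 1.2-fold higher number from compound 1 to compound 4 (0.07 log units; within the scatter) in this case. Compound 4 is estimated at 28000 nM with an expected range from 16000 nM to 48000 nM for a measurement.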

Compound 4, half-maximal inhibitory concentration: 24500 nM
Beside the measured number, compound 4's estimate is 1.1-fold (0.06 log units) above it; the measured number falls inside the stated range.
By their numbers in this assay, from the lowest: compounds 1, 4, 3 and 2 (each within the scatter of the next).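

In this assay, among these compounds, the new bromo compound reads as a 1.0-fold higher number from compound 1 to compound 4 (0.01 log units; within the scatter) and a 1.2-fold lower number from compound 3 to compound 4 (0.06 log units; within the scatter) and also a 1.3-fold lower number from compound 2 to compound 4 (0.12 log units; within the scatter), so it cannot be separated from any of the earlier compounds. The 4-bromophenyl group thus joins 2-methylphenyl, 4-methylphenyl and 4-chlorophenyl as a fourth group on the saturated chain carbon bound to a sulfur that these numbers cannot tell apart, and bromo cannot be told from chloro or methyl on the aromatic carbon. No evidence is available to explain why these four compounds lie so close together.

As far as these compounds go, whether an amine or a carboxylic acid on the phenyl ring, or a longer chain in place of the benzyl group, would give a step beyond the scatter stays open. From the compounds shown here alone, all four compounds also share one core, so the effect of altering that core remains unknown.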